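The source may hold more compounds than are shown below. What is called first, only, known or untested is meant among the compounds shown, and "the series" means these compounds.

Compound 1 `C/C(=C\c1cc(-c2ccc(C)nc2)co1)C(N)=O` and compound 2 `C/C(=C\c1cc(-c2ccc(F)nc2)co1)C(N)=O` share one core and differ in a single spot: fluoro in place of methyl on an aromatic carbon. In a functional assay on MCF7 cells (Homo sapiens) for cytotoxicity, read by CCK-8 assay, with a stated time of 24 h (a higher number here means a weaker inhibitor, a lower number a stronger inhibitor), compound 1 gives 10200 nM. In this assay compound 2 gives 14100 nM. The step between the two is a 1.4-fold higher number from compound 1 to compound 2 (0.14 log units; within the scatter), so the swap of methyl for fluoro left the read-out essentially unchanged.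

Compound 3 `C/C(=C\c1nc(-c2ccc(C)cc2)cs1)C(N)=O` is built on a different core; the difference between the two cores is not broken down here. In this assay compound 3 reaches only the limit of the measurement, > 50000 nM, and no number is reported for it (the limit of > 50000 nM in this assay, at which 1 of the 3 values shown sits).

Compound 4 `C/C(=C\c1nc(-c2ccc(F)cc2)cs1)C(N)=O`, not yet measured, differs from compound 3 by the same kind of change: fluoro in place of methyl on an aromatic carbon. Here the ring is of carbon only, whereas in compound 1 the ring holds 1 nitrogen and the change sits next to the ring nitrogen. For compound 4 the expected step is a step that the limit leaves unreadable from compound 3 to compound 4, small, like the one already seen. That expectation rests on the measured step, which was a 1.4-fold higher number from compound 1 to compound 2 (0.14 log units; within the scatter). Compound 4 is therefore expected to give 70000 nM, most likely again only as a limit.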

Compound 4, half-maximal inhibitory concentration: 3300 nM
For compound 4 the middle estimate is 21-fold (1.33 log units) above the measured one, outside the stated range (below it).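

Placing fluoro in place of methyl on an aromatic carbon gives an at least 15-fold lower number from compound 3 to compound 4 (1.18 log units; beyond the scatter) in this assay, so a swap that left the read-out essentially unchanged on the core of compound 1 has a large effect on the core of compound 3. The outcome of this swap on one core therefore cannot simply be assumed for the other, as the two steps side by side show: the same change on two cores in this assay, a 1.4-fold higher number (0.14 log units; within the scatter) from compound 1 to compound 2 and an at least 15-fold lower number (1.18 log units; beyond the scatter) from compound 3 to compound 4, at least 20-fold (1.32 log units) apart, beyond the scatter of two such steps For compound 3 the read-out is only a limit, > 50000 nM, and these two pairs do not show which part of the two cores, or what about them, sets the steps apart.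

From the compounds shown here alone, it remains open whether other groups on the same aromatic carbon, such as chloro, methoxy or an amine, would follow the pattern of fluoro on either core. Going by these compounds, it is also open how either core would respond if the amide were replaced by a carboxylic acid, or if the methyl on the linking chain gave way to a longer chain.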